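A Second Methoxy Group on Compound 2

The source may hold more compounds than are shown below. What is called first, only, known or untested is meant among the compounds shown, and "the series" means these compounds.

Compound 1 `CCC1=C(O)c2c(oc(-c3ccc(SC)cc3)cc2=O)C(CC)(CC)C1=O`: > 52.1 uM (a limit of the assay, not a number)
Compound 2 `CCC1=C(O)c2c(oc(-c3cccc(OC)c3)cc2=O)C(CC)(CC)C1=O`: 13.3 uM
Compound 3 `CCC1=C(O)c2c(oc(-c3cccc(OC)c3OC)cc2=O)C(CC)(CC)C1=O`: 35.2 uM

All three compounds were tested in a functional assay on KB cells (Homo sapiens) for antiproliferative activity, read by sulforhodamine B assay, with a stated time of 3 days; a lower number here means that less compound is needed, a higher number that more compound is needed for the effect. Compound 1 gave only a limit, > 52.1 uM. Of the two actual numbers, compound 2 holds the lower one, 13.3 uM, and its nearest neighbour is compound 3 at 35.2 uM.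

The untested compound 4 `CCC1=C(O)c2c(oc(-c3cc(OC)cc(OC)c3)cc2=O)C(CC)(CC)C1=O` differs from compound 2 by one change: methoxy in place of hydrogen on an aromatic carbon. The new methoxy sits on an aromatic carbon, meta to the methoxy group already present and meta to a large group.

One measured step resembles this change: a 2.6-fold higher number from compound 2 to compound 3 (0.42 log units; beyond the scatter). It also puts methoxy in place of hydrogen on an aromatic carbon, though at a different place on the ring. The other step, an at least 3.9-fold lower number from compound 1 to compound 2 (0.59 log units; beyond the scatter), exchanges a whole substituent and starts from a limit, so it offers little guidance here. A single step is thin support, but a modest rise in this assay is the most reasonable expectation. The expected change is a 1.8-fold higher number from compound 2 to compound 4 (0.26 log units; within the scatter). Compound 4 is estimated at 24 uM, with an expected range from 9 uM to 55 uM.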

Compound 4, concentration for half-maximal effect: 45.2 uM
The estimate for compound 4 lay 1.9-fold (0.27 log units) below the measured number; the measured number falls inside the stated range.
By their numbers in this assay, from the lowest: compound 2; then compounds 3 and 4 (each within the scatter of the next). At a limit, above all of these: compound 1.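

In this assay, a second methoxy group placed meta to the methoxy group already present and meta to a large group gives a 3.4-fold higher number from compound 2 to compound 4 (0.53 log units; beyond the scatter). The other placement shown gives a 2.6-fold higher number from compound 2 to compound 3 (0.42 log units; beyond the scatter), so the rise in the number is not confined to one place on the ring, and among these compounds the single methoxy group of compound 2 gives the lowest actual number, while compounds 3 and 4 lie within the scatter of each other and cannot be ranked. Compound 1 gives only a limit, not a number: the limit of > 52.1 uM in this assay, at which 1 of the 4 values shown sits.

These compounds cannot separate the effect of this place on the ring from the effect of the methoxy group itself, since methoxy is the only group shown entering there. As far as these compounds go, whether a hydroxy group, an amine or a longer chain such as ethoxy at the same place would also raise the number, or would instead lower it below that of compound 2, remains open.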